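The compounds below may be only part of what the source reports. "The series", "measured", "known", "first", "only" and "open" are said of these compounds alone.

Measured compounds:
- compound 1, `C=CC1=C(C(=O)Nc2ccccc2)C(c2ccc(F)cc2)OC1`, gives > 100000 nM, which is a limit of the assay and not a number.
- compound 2, `C=CC1=C(C(=O)NCCCCC)C(c2ccc(F)cc2)OC1`, gives > 100000 nM, again a limit of the assay rather than a number.

Both readings come from a functional assay on HeLa cells (Homo sapiens) for cytotoxicity, read by MTT assay, with a stated time of 24 h; a higher number here means a weaker inhibitor, a lower number a stronger inhibitor. Because (the limit of > 100000 nM in this assay, at which 2 of the 2 values shown sit), neither compound shows a measurable number, so the step from compound 1 to compound 2 (a step that the two limits leave unreadable from compound 1 to compound 2) cannot be read in size or direction; it is only known that pentyl in place of phenyl on an amide-type nitrogen left the reading at the limit.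

The unmeasured compound 3, `C=CC1=C(C(=O)NC2CCCCC2)C(c2ccc(F)cc2)OC1`, differs from compound 2 in one place: cyclohexyl in place of pentyl on an amide-type nitrogen. Going by the values given here, the only measured step, the one from compound 1 to compound 2, bears on a change at the same amide-type nitrogen, but its size is unreadable, so no direction can be drawn from it. With both neighbours at the limit, compound 3 is expected to sit there as well, giving in this assay an estimated 150000 nM, in the range 50000 nM to 600000 nM. The expected step that the limit leaves unreadable from compound 2 to compound 3 is therefore none beyond the scatter.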

Compound 3, half-maximal inhibitory concentration: > 100000 nM
Compound 3 was reported as a limit (the forecaster's own chance of this, stated with the estimate: 85%); the middle value lies beyond the limit too.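

Compound 3, like compound 1 and compound 2, is reported in this assay only as a limit and not as a number, so no step among these three compounds can be read in size or direction: the limit of > 100000 nM in this assay, at which 3 of the 3 values shown sit. The compounds shown leave open whether phenyl, pentyl or cyclohexyl on the amide-type nitrogen makes any difference to the reading.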